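The source may report more compounds than this note shows. Statements on the series, on what has been measured and on what is new or still open speak of the compounds shown alone.

Working notes on the series. Three compounds have readings in an assay on HEK293 cells for binding affinity to prostaglandin E2 receptor EP2 subtype (Rattus norvegicus); on this read-out higher numbers stand for weaker inhibition and lower numbers for stronger inhibition. Compound 1 `O=C(O)CCCCCCN1C(=O)CC[C@@H]1CC[C@@H](O)CCc1ccccc1` gives only a limit of this assay, > 3200 nM. Compound 2 `O=C(O)c1ccc(CCCN2C(=O)CC[C@@H]2CCC(O)Cc2ccc3ccccc3c2)s1` likewise returns a limit, > 3200 nM. Compound 3 `O=C(O)c1ccc(CCCN2C(=O)CCC2CCC(O)Cc2ccc(F)cc2)cc1` also sits at a limit, > 3200 nM. Compound 2 therefore stands at the limit of > 3200 nM in this assay, at which 3 of the 3 values shown sit, and no ordering among the three is possible. Compound 4 `CCc1ccc(CC(O)CC[C@H]2CCC(=O)N2CCCc2ccc(C(=O)O)s2)cc1` differs from compound 2 by 4-ethylphenyl in place of naphthalen-2-yl on a saturated chain carbon, two bonds along the chain from an oxygen on a saturated carbon. For the measured compounds named here, no measured step bears on this change, so no shift beyond the scatter is expected in either direction. The expected step that the limit leaves unreadable from compound 2 to compound 4 is accordingly set near zero. Compound 4 is estimated at 5000 nM, within 1500 nM to 30000 nM, with a reading that is again only a limit considered the likeliest outcome.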

Compound 4, half-maximal inhibitory concentration: 1200 nM
Beside the measured number, compound 4's estimate is 4.2-fold (0.62 log units) above it; measured number below the stated range.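

In this assay, this position on the saturated chain carbon responds to the substituent: 4-ethylphenyl in place of naphthalen-2-yl gives an at least 2.6-fold lower number from compound 2 to compound 4 (0.42 log units; beyond the scatter). Compound 4 is the only compound shown with a number rather than a limit, so the series now has a measurable starting point. The size of the step remains a lower bound because the reading for compound 2 is only a limit: the limit of > 3200 nM in this assay, at which 3 of the 4 values shown sit.

Still open, as far as these compounds go, is whether the ethyl group or the change from two aromatic rings to one accounts for the step. Unsubstituted phenyl or 4-propylphenyl at this position would help separate the two.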